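The source may hold more compounds than are shown below. What is called first, only, known or untested is meant among the compounds shown, and "the series" means these compounds.

In an ADME assay on microsomes from liver (Homo sapiens) for metabolic stability, read by LC-MS, using NADPH, with a stated time of 45 min, tested at 3 uM (on this read-out higher numbers stand for a longer-lived compound and lower numbers for a shorter-lived compound), compound 3 `c1ccc(C(CC2CCCCN2)C2CCCCC2)cc1` gives 0.933 h. This is level, within the scatter, with compound 2 `C1CCC(CC(C2CCCC2)C2CCC2)NC1` at 0.85 h, while compound 1 `C1CCC(C(CC2CCCCN2)C2CC2)CC1` stands clearly higher at 2.07 h. Compound 4 `FC1CCC(C(CC2CCCCN2)C2CCCCC2)CC1` differs from compound 3 in one place: it has 4-fluorocyclohexyl in place of phenyl on a saturated chain carbon bound to a saturated chain carbon and a saturated ring carbon.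

Among the compounds with values here, one measured step bears on this change: a 2.2-fold lower number from compound 1 to compound 3 (0.35 log units; beyond the scatter), with phenyl entering in place of cyclopropyl. That modest step hints that removing phenyl could lengthen the half-life, but the group replaced there is a different one. Compound 2 also tempers the hint, since it carries no phenyl and still gives 0.85 h. Within the data shown here, no measured compound carries fluorine, so that part of the change has no guide. The expected change is only a slight rise, not beyond the scatter, with an estimated step of a 1.4-fold higher number from compound 3 to compound 4 (0.14 log units; within the scatter). For compound 4 the estimated half-life is 1.3 h, with an expected range from 0.6 h to 2.8 h.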

Compound 4, half-life: 1.08 h
The estimate for compound 4 lay 1.2-fold (0.08 log units) above the measured number; the measured number falls inside the stated range.
By their numbers in this assay, from the lowest: compounds 2, 3, 4 and 1 (each within the scatter of the next, the first and the last beyond it).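

In this assay, a saturated ring carrying fluorine can stand on this chain carbon in place of the aromatic phenyl ring without a readable effect on half-life: the step is a 1.2-fold higher number from compound 3 to compound 4 (0.06 log units; within the scatter) and the two compounds count as level. Compound 4 also cannot be separated from the cyclopropyl compound, with the step of a 1.9-fold lower number from compound 1 to compound 4 (0.28 log units; within the scatter) staying inside the scatter, whereas the step of a 2.2-fold lower number from compound 1 to compound 3 (0.35 log units; beyond the scatter) lay beyond it, so compound 4 sits level with both of two compounds that do differ from each other. No measurement here offers an explanation for this result.

The compounds shown do not separate what the fluorine contributes from what the saturated ring contributes. From the compounds shown here alone, how an amine or a carboxylic acid on that ring, or a longer chain on this carbon, would read also remains open.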